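The compounds below may be only part of what the source reports. "The series", "measured", "known", "first", "only" and "open" are said of these compounds alone.

Compound 1 `O=C(NCc1ccc(S(=O)(=O)c2ccccc2)cc1)NCc1cccnc1`: 10000 nM
Compound 2 `O=S(=O)(c1ccccc1)c1ccc(CNS(=O)(=O)N2Cc3ccncc3C2)cc1`: 3000 nM
Compound 3 `CC(C)n1cc(S(=O)(=O)c2ccc(CNC(=O)N3Cc4ccncc4C3)cc2)cn1`: 192000 nM

In a physicochemical assay for solubility, in phosphate buffer, with a stated time of 24 h, at pH 7.4, tested at 100 uM (a higher number here means a more soluble compound, a lower number a less soluble compound), compound 3 gives 192000 nM, the highest of the three numbers. Compound 1 gives 10000 nM in this assay, and the gap between compound 3 and compound 1 lies beyond the scatter. Compound 2 gives 3000 nM in this assay, which is the number furthest from that of compound 3, again beyond the scatter. Compound 4 `O=C(NCc1ccc(S(=O)(=O)N2CCC(O)CC2)cc1)N1Cc2ccncc2C1` has not yet been measured in this assay. It differs from compound 3 in one place: 4-hydroxypiperidin-1-yl in place of 1-isopropyl-1H-pyrazol-4-yl on a sulfonyl sulfur. Among the compounds with values here, no step between two measured compounds covers this change, so the account rests on the three numbers alone. The expectation is that the step from compound 3 to compound 4 in this assay stays within the scatter, with no clear direction, because compound 3 already gives 192000 nM and the entering group carries a hydrogen-bond donor in place of a five-membered aromatic ring. Compound 4 is therefore expected to give about 160000 nM in this assay, within a range from 45000 nM to 400000 nM, which amounts to an expected step of a 1.2-fold lower number from compound 3 to compound 4 (0.08 log units; within the scatter).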

Compound 4, solubility: 174000 nM
Compound 4: middle estimate off by 1.1-fold (0.04 log units), on the low side, and the stated range covers the measured number.
By their numbers in this assay, from the lowest: compound 2; then compound 1; then compounds 4 and 3 (each within the scatter of the next).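

In this assay, within the data shown here, the exchange on the sulfonyl sulfur amounts to a 1.1-fold lower number from compound 3 to compound 4 (0.04 log units; within the scatter) and gives the first reading at this position. A five-membered aromatic ring with no hydrogen-bond donor and a six-membered non-aromatic ring with one hydrogen-bond donor give numbers that cannot be told apart on that sulfur, so this position accepts both groups without a measurable difference in this read-out. Nothing measured here explains why the two numbers stand level.

The compounds shown leave open whether a plain piperidin-1-yl group, without the hydroxyl, would give a number in the same range. They also leave open how a group carrying a carboxylic acid or a primary amine would read on the same sulfonyl sulfur.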